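Shortening the chain on an aromatic nitrogen

The source may hold more compounds than are shown below. What is called first, only, known or untested is meant among the compounds shown, and "the series" means these compounds.

The study follows four compounds built on one shared core, tested in a functional assay on MDA-MB-231 cells (Homo sapiens) for cytotoxicity, read by MTT assay, with a stated time of 48 h; on this read-out lower numbers stand for stronger inhibition and higher numbers for weaker inhibition. Compound 2 `CC(C)n1c(/C=C2/C(=O)Nc3ccccc32)nc2ccccc21` carries an isopropyl group, and in this assay compound 2 gives 30400 nM. Compound 1 `CCn1c(/C=C2/C(=O)Nc3ccccc32)nc2ccccc21` carries an ethyl group in its place. The reading for compound 1 is a limit of the assay and not a number: in this assay compound 1 gives > 50000 nM. The change between them is hydrogen in place of methyl on a saturated chain carbon bound to an aromatic nitrogen and a saturated chain carbon. Within the data shown here, the step of an at least 1.6-fold higher number from compound 2 to compound 1 (0.21 log units; that floor lies within the scatter) is the only measured step, and it rests on (the limit of > 50000 nM in this assay, at which 1 of the 3 values shown sits).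

Compound 3 `CCn1c(/C=C2/C(=O)Nc3ccc(Br)cc32)nc2ccccc21` keeps the ethyl group and carries a bromine; in this assay compound 3 gives "not determined" (no result reported). The difference between the core of compound 3 and the core of compound 2 is not broken down here.

Compound 4 `Cn1c(/C=C2/C(=O)Nc3ccc(Br)cc32)nc2ccccc21` has not been tested. It differs from compound 3 by hydrogen in place of methyl on a saturated chain carbon bound to an aromatic nitrogen. Among the measured compounds shown here, this is the same kind of change as the one from compound 2 to compound 1, though the place is not the same: in compound 2 the carbon is bound to an aromatic nitrogen and a saturated chain carbon, in compound 3 it is bound to an aromatic nitrogen only. Since compound 3 has no number, the expectation for compound 4 rests only on the direction of an at least 1.6-fold higher number from compound 2 to compound 1 (0.21 log units; that floor lies within the scatter), toward a weaker inhibition, and on the limit reached by compound 1. Compound 4 is therefore expected to give roughly 60000 nM in this assay, estimated to fall between 20000 nM and 200000 nM, with a fair chance that only a limit is reported.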

Compound 4, half-maximal inhibitory concentration: > 50000 nM
Compound 4: a limit, no number (the forecaster's own chance of this, stated with the estimate: 55%); the middle value lies beyond the limit too.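

In this assay compound 4 gives > 50000 nM as a limit of the assay and not a number. Among these compounds, compound 3 gives "not determined" (no result reported) in this assay and so no step between compound 3 and compound 4 can be read. The compounds shown leave open how far the change from ethyl to methyl moves the reading where the bromine is present, and what the bromine itself contributes.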